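The compounds below may be only part of what the source reports. "The series", "measured", "known", "first", "only" and "open" are said of these compounds alone.

Measured in an ADME assay on microsomes from liver (Homo sapiens) for metabolic stability, with a stated time of 10 min; a lower number here means that less of the compound is left, a higher number that more of the compound is left:
- compound 1 `CCSc1nn2cc(-c3cc4ccccc4o3)nc2s1`: 45%
- compound 2 `COc1cc(OCc2cccc(CCc3ccccc3)c2)c2cc(-c3cn4nc(OC)sc4n3)oc2c1`: 99%
- compound 3 `COc1cc(OCc2cccc(Sc3ccccc3)c2)c2cc(-c3cn4nc(OC)sc4n3)oc2c1`: 80%

Not yet measured: compound 4 `Cc1nn2cc(-c3cc4ccccc4o3)nc2s1`.

Compound 1 is the lowest of the three, beyond the scatter from both compound 3 and compound 2. Compound 4 differs from compound 1 by methyl in place of ethylsulfanyl on an aromatic carbon. For the measured compounds named here, no measured compound shows this change. Going by the values given here, the only measured single-place step, a number 19 percentage points lower from compound 2 to compound 3 (beyond the scatter), involves other groups, so it bears only loosely. It suggests what size a single swap can reach in this small set, but gives no direction for this one. Only the low starting point of compound 1 at 45% suggests an upward move, and weakly. A modest rise is therefore expected in this assay, estimated as a number 12 percentage points higher from compound 1 to compound 4 (beyond the scatter), with a real chance of no change beyond the scatter. For compound 4 the estimated value is 57%, with an expected range of 35% to 80%.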

Compound 4, percent of the compound remaining: 20%
Compound 4: the middle estimate sits 37 percentage points above what was measured, and the stated range ends above it.
By their numbers in this assay, from the lowest: compound 4; then compound 1; then compound 3; then compound 2.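

Methyl in place of ethylsulfanyl on this aromatic carbon, on the five-membered aromatic ring with 2 nitrogen and 1 sulfur, gives a number 25 percentage points lower from compound 1 to compound 4 (beyond the scatter) in this assay and is the first change read at this position. The position is therefore not silent in this read-out, and within this pair more of the compound is left with ethylsulfanyl than with methyl. No measurement shown accounts for the drop.

As far as these compounds go, it remains open whether the step follows the loss of the sulfur or the shorter chain, and ethyl or propylsulfanyl on the same carbon would separate the two. An amine at this position would show how far the read-out moves with a group of another kind on the core of compound 1.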